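Cytotoxicity notes: the step from compound 3 to compound 4

This account rests on a few compounds, and the source may have more. Where it says the series, first, only, none or still open, it means among the compounds named here.

Compound 1 `CCOC(=O)CCCCCOc1cccc(CN(C(=O)c2ccc(-c3cccc(NC(C)=O)c3)cc2)C(C)C)c1` stands in an ADME assay on BJ cells (Homo sapiens) for cytotoxicity, read by CellTiter-Glo and resazurin assay, with a stated time of 72 h (on this read-out lower numbers stand for an effect already at smaller amounts and higher numbers for an effect only at larger amounts of compound), only at a limit of the assay, > 26000 nM, not at a number. Compound 2 `CCOC(=O)CCCCCOc1cccc(CN(C(=O)c2ccc(-c3cccc(Oc4ccccc4)c3)cc2)C(C)C)c1` likewise gives in this assay only a limit, > 19600 nM. Compound 3 `CCOC(=O)CCCCCOc1cccc(CN(C(=O)c2ccc(-c3cccc(S(C)(=O)=O)c3)cc2)C(C)C)c1` also stands in this assay at a limit, > 26000 nM, so its place among the values shown cannot be read more finely than that. The three steps connecting these compounds are therefore blank: a step that the two limits leave unreadable from compound 1 to compound 2, a step that the two limits leave unreadable from compound 1 to compound 3 and a step that the two limits leave unreadable from compound 2 to compound 3. What the values have in common is the limit of > 19600 nM in this assay, at which 1 of the 3 values shown sits, and (the limit of > 26000 nM in this assay, at which 2 of the 3 values shown sit).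

Compound 4 `CCOC(=O)CCCCCOc1cccc(CN(C(=O)c2ccc(-c3cccc([N+](=O)[O-])c3)cc2)C(C)C)c1` differs from compound 3 in one place: nitro in place of methylsulfonyl on an aromatic carbon. Within the data shown here, no measured step with a readable size bears on this change; the steps touching compound 3 are unreadable, and each substituent so far on that aromatic carbon has left the value at a limit. The step in this assay expected here is a step that the limit leaves unreadable from compound 3 to compound 4, meaning no move beyond the scatter that the limits could show. Compound 4 is therefore expected to give in this assay 30000 nM, within a range from 15000 nM to 60000 nM, most likely reported once more only as a limit.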

Compound 4, half-maximal effective concentration: < 1.3 nM
Compound 4: only a limit was reported; the forecaster's own chance of this, stated with the estimate: 85%; middle value at least 23000-fold (4.36 log units) away from the limit.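

In this assay, the substituent on this aromatic carbon can decide the reading: nitro in place of methylsulfonyl gives an at least 20000-fold lower number from compound 3 to compound 4 (4.30 log units; beyond the scatter), nitro in place of phenoxy gives an at least 15000-fold lower number from compound 2 to compound 4 (4.17 log units; beyond the scatter), and nitro in place of acetamido gives an at least 20000-fold lower number from compound 1 to compound 4 (4.30 log units; beyond the scatter). The steps among compound 1, compound 2 and compound 3 cannot be read, so those compounds gave no sign that one group at this place, on an otherwise unchanged structure, could set a compound apart so sharply. Compound 4 alone stands at the low end of the values shown, and its reading is a limit, not a number: the limit of < 1.3 nM in this assay, at which 1 of the 4 values shown sits.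

The compounds shown leave open whether this step belongs to nitro alone or also appears with an amine or a nitrile on the same aromatic carbon. Going by these compounds, how far the true value of compound 4 lies from its limit also stays open, as does whether the step holds with a carboxylic acid in place of the ester.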